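A few compounds are considered here, and "the series" means these few. Any claim that something is new, unique, unknown or untested is made for them only; others in the source may bear on it.

Three measured compounds, each in a functional assay on the whole organism for agonist activity, with Mus musculus as the target; a lower number here means that less compound is needed, a higher number that more compound is needed for the effect:
Compound 1, `CC(C#CCn1ccnc1)N1CCCC1=O`, reaches only the assay limit, > 100 mg/kg.
Compound 2, `Cc1cncn1CC#CC(C)N1CCCC1=O`, also sits at the assay limit, > 100 mg/kg.
Compound 3, `CC1CCC(=O)N1CC#CCn1ccnc1`, likewise stops at the assay limit, > 100 mg/kg.

Compound 2 arises from compound 1 by a single change, (methyl in place of hydrogen on an aromatic carbon). The step that the two limits leave unreadable from compound 1 to compound 2 cannot be read, because of the limit of > 100 mg/kg in this assay, at which 3 of the 3 values shown sit. Compound 3 is built from the same atoms as compound 1, joined differently; the difference between the two cores is not broken down here.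

The compound still to be measured is compound 4, `Cc1cncn1CC#CCN1C(=O)CCC1C`. It arises from compound 3 by methyl in place of hydrogen on an aromatic carbon, the same change as from compound 1 to compound 2, since the place described for both is the same word for word. The expected step that the limit leaves unreadable from compound 3 to compound 4 rests on the fact that every value gathered so far is a limit, (the limit of > 100 mg/kg in this assay, at which 3 of the 3 values shown sit). Compound 4 is therefore expected to give about 200 mg/kg in this assay, most likely once more only a limit, with the estimate spanning 60 mg/kg to 1000 mg/kg.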

Compound 4, dose for half-maximal effect: > 100 mg/kg
Compound 4: a limit, no number (the forecaster's own chance of this, stated with the estimate: 85%); the middle value is on the limit's open side.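

No size can be given for the step from compound 3 to compound 4, since both results are limits and not numbers: the limit of > 100 mg/kg in this assay, at which 4 of the 4 values shown sit. The compounds shown leave open what dose any of them needs in this assay, and whether methyl in place of hydrogen on the aromatic carbon changes that dose at all.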